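Swapping chloro for bromo in a weakly cytotoxic series

This account rests on a few compounds, and the source may have more. Where it says the series, first, only, none or still open, it means among the compounds named here.

Measured in a functional assay on K562 cells (Homo sapiens) for cytotoxicity, read by MTT assay, with a stated time of 24 h; on this read-out higher numbers stand for weaker inhibition and lower numbers for stronger inhibition:
Compound 1 `COc1cc(/C=C2\CN(C)C/C(=C\c3ccc(Br)cc3)C2=O)cc(OC)c1`: 7420 nM
Compound 2 `COc1cc(/C=C2\CN(C)C/C(=C\c3ccc(F)cc3)C2=O)cc(OC)c1OC`: 10300 nM
Compound 3 `COc1cc(/C=C2\CN(C)C/C(=C\c3ccc(Cl)cc3)C2=O)cc(OC)c1OC`: > 20000 nM (a limit, not a number)

Compound 3 stands at the limit of > 20000 nM in this assay, at which 1 of the 3 values shown sits, so its true value is not known. Compound 4 `COc1cc(/C=C2\CN(C)C/C(=C\c3ccc(Br)cc3)C2=O)cc(OC)c1OC` differs from it in one place: bromo in place of chloro on an aromatic carbon. In words, this is bromo in place of chloro on an aromatic carbon, which turns 4-chlorophenyl into 4-bromophenyl.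

The closest measured step is chloro in place of fluoro, an at least 1.9-fold higher number from compound 2 to compound 3 (0.28 log units; that floor lies within the scatter). On its own, that step shows no change beyond the scatter. Compound 1 also carries 4-bromophenyl and gives 7420 nM, but the rest of its structure differs from that of compound 4, so it is only a loose guide. It does suggest that a bromo compound can give a readable number in this assay. No step beyond the scatter is therefore expected, and compound 4 may again reach the limit. The expected change is an at least 1.2-fold lower number from compound 3 to compound 4 (0.09 log units; that floor lies within the scatter). For compound 4 the estimated value is 16000 nM, with an expected range of 7000 nM to 30000 nM.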

Compound 4, half-maximal inhibitory concentration: 12400 nM
The estimate for compound 4 lay 1.3-fold (0.11 log units) above the measured number, and the stated range covers the measured number.
By their numbers in this assay, from the lowest: compounds 1, 2 and 4 (each within the scatter of the next). At a limit, above all of these: compound 3.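

In this assay compound 3, with chloro at this position, stands at a limit and not at a number: the limit of > 20000 nM in this assay, at which 1 of the 4 values shown sits. Bromo at the same position gives a readable number, but the change from chloro to bromo is not shown to be a real one (an at least 1.6-fold lower number from compound 3 to compound 4 (0.20 log units; that floor lies within the scatter)), and bromo cannot be told apart from fluoro on the same core (a 1.2-fold higher number from compound 2 to compound 4 (0.08 log units; within the scatter)). The pair that shares 4-bromophenyl adds a further point, since methoxy in place of hydrogen on an aromatic carbon also leaves the result within the usual scatter (a 1.7-fold higher number from compound 1 to compound 4 (0.22 log units; within the scatter)).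

On these data alone, the true value of compound 3 remains unknown, so it is still unclear whether chloro really stands apart from the other two halogens or only appears to because its result is a limit. As far as these compounds go, what an amine, a carboxylic acid or a longer chain would do at this position also remains open, so these compounds show only how three halogens compare here and say nothing about how far the position can be changed.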